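A few compounds are considered here, and "the series" means these few. Any claim that something is new, unique, unknown or untested is made for them only; others in the source may bear on it.

In an ADME assay on A549 cells (Homo sapiens) for cytotoxicity, read by resazurin assay, with a stated time of 48 h (a lower number here means that less compound is tolerated, a higher number that more compound is tolerated), three compounds have been measured:

Compound 1, `CCNc1ccc(NC(=O)c2cc(Cl)ccc2O)c(Cl)c1`, gives 30200 nM.
Compound 2, `CC1(ON(c2ccc(NC(=O)c3cc(Cl)ccc3O)c(Cl)c2)C2(C)CCCC2)CCCC1`, gives 18000 nM.
Compound 3, `O=C(Nc1ccc(NCc2cc(F)cc(C(F)(F)F)c2)cc1Cl)c1cc(Cl)ccc1O`, gives 30900 nM.

Compound 1 holds the second highest of these three numbers, but neither neighbour is truly apart from it: compound 3 sits closest, and even compound 2, the furthest away, lies within the usual scatter of repeated runs. In practice the three compounds are tolerated by the cells to about the same degree, and no ordering among them can be claimed.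

The next compound to be tested is compound 4, `CC(C)(C)OC(=O)NCCNc1ccc(NC(=O)c2cc(Cl)ccc2O)c(Cl)c1`. It keeps the whole of compound 1 and differs from it in a single place: (tert-butoxycarbonyl)amino in place of hydrogen on a saturated chain carbon, two bonds along the chain from a nitrogen on an aromatic ring. The added group is a common protecting group on a short chain hanging from the core, and nothing in the three measured compounds points to a change of tolerance beyond the scatter.

Within the data shown here, compound 4 is therefore expected to show essentially no step in this assay, with a 1.1-fold lower number from compound 1 to compound 4 (0.05 log units; within the scatter) as the estimated shift, because compound 1 gives 30200 nM and the other two compounds cluster close to it. The estimate for compound 4 is 27000 nM, with a range from 11000 nM to 65000 nM.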

Compound 4, half-maximal cytotoxic concentration: 25000 nM
Estimate against measurement, compound 4: 1.1-fold (0.03 log units) above; the range from low to high includes it.
By their numbers in this assay, from the lowest: compounds 2, 4, 1 and 3 (each within the scatter of the next).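

Among these compounds, until now, no two measured compounds differed in only one place, so this assay had not yet given a direct reading of a single change to the core of compound 1. This pair supplies that reading, and a 1.2-fold lower number from compound 1 to compound 4 (0.08 log units; within the scatter) is the step that comes with swapping hydrogen for (tert-butoxycarbonyl)amino on a saturated chain carbon, two bonds along the chain from a nitrogen on an aromatic ring. The step shows that this position can take a group of 8 heavy atoms, with no ring and with 1 hydrogen-bond donor and 2 hydrogen-bond acceptors, without moving the number beyond the usual scatter, though no measurement here accounts for why that is so.

This is one group at one position, so it cannot be read as a general rule that anything placed on this chain will leave the number within the scatter. The compounds shown leave open what a free primary amine at the same carbon would give, and equally what a carboxylic acid or a longer chain ending in either group would give in this assay on these cells.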